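A few compounds are considered here, and "the series" means these few. Any claim that something is new, unique, unknown or untested is made for them only; others in the source may bear on it.

Compound 1 `Cc1ccc(-c2nnc(-c3ccc(CN4CCN(C)CC4)c(C(F)(F)F)c3)o2)cc1Nc1nccc(-c2cccnc2)n1` in a functional assay on HL-60 cells (Homo sapiens) for inhibition, read by MTT assay, with a stated time of 72 h; on this read-out higher numbers stand for weaker inhibition and lower numbers for stronger inhibition: 50 nM.
Compound 2 `Cc1ccc(-c2nnc(-c3ccc(C)c(C(F)(F)F)c3)o2)cc1Nc1nccc(-c2cccnc2)n1`: > 30000 nM, which is a limit of the assay rather than a number.
Compound 3 `Cc1ccc(-c2nnc(-c3ccc(F)c(C(F)(F)F)c3)o2)cc1Nc1nccc(-c2cccnc2)n1`: > 30000 nM, also a limit of the assay, not a number.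

Among the three, only compound 1 gives a number in this assay; compound 2 and compound 3 stop at the limit (the limit of > 30000 nM in this assay, at which 2 of the 3 values shown sit), so where compound 3 stands can be told only as a limit and not as a number. Compound 4 `Cc1ccc(-c2nnc(-c3ccc(CN4CCN(CCN)CC4)c(C(F)(F)F)c3)o2)cc1Nc1nccc(-c2cccnc2)n1` has not yet been measured. It differs from compound 3 by (4-(2-aminoethyl)piperazin-1-yl)methyl in place of fluoro on an aromatic carbon. The measured step that bears most directly on this is the reverse of an at least 600-fold higher number from compound 1 to compound 3 (2.77 log units; beyond the scatter), where fluoro in place of (4-methylpiperazin-1-yl)methyl moved the value from a number to the limit. an at least 600-fold higher number from compound 1 to compound 2 (2.77 log units; beyond the scatter) points the same way for the related loss of the 4-methylpiperazin-1-yl group. The step from compound 2 to compound 3 cannot be read, since both stand at the limit. Putting a piperazinylmethyl group back, now carrying a 2-aminoethyl, is expected to bring compound 4 down from the limit by a large step, an at least 300-fold lower number from compound 3 to compound 4 (2.47 log units; beyond the scatter). Compound 4 is estimated at 100 nM, with a range from 30 nM to 600 nM.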

Compound 4, half-maximal inhibitory concentration: 20 nM
The estimate for compound 4 lay 5.0-fold (0.70 log units) above the measured number; the measured number lies below the stated range.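

Placing (4-(2-aminoethyl)piperazin-1-yl)methyl on this aromatic carbon, ortho to the trifluoromethyl group, gives an at least 1500-fold lower number from compound 3 to compound 4 (3.17 log units; beyond the scatter) in this assay, and the same comparison against the methyl-bearing ring gives an at least 1500-fold lower number from compound 2 to compound 4 (3.17 log units; beyond the scatter), so a methyl on the piperazine is not required for strong inhibition. Swapping that methyl for 2-aminoethyl also shifts the value, giving a 2.5-fold lower number from compound 1 to compound 4 (0.40 log units; beyond the scatter), a modest step. Compound 2 and compound 3 each give a limit rather than a number, so the two large steps are minimum sizes: the limit of > 30000 nM in this assay, at which 2 of the 4 values shown sit.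

As far as these compounds go, whether the gain comes from the terminal amine or simply from the longer chain stays open, and a 2-hydroxyethyl or plain ethyl on the piperazine would separate the two. Also open, from the compounds shown here alone, is whether the piperazine ring itself is needed, which a morpholine or an open-chain dimethylamine on the same carbon would test.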